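A few compounds are considered here, and "the series" means these few. Any claim that something is new, unique, unknown or untested is made for them only; others in the source may bear on it.

Compound 1 `Clc1cc(Cl)cc(CO[C@H]2CCCN(Cc3ccccn3)[C@H]2c2ccccc2)c1` is known in an assay on isolated protein for activation of cGMP-dependent protein kinase 1 (Homo sapiens), read by ADP-Glo, with stated times of 120 min and 40 min (on this read-out lower numbers stand for an effect already at smaller amounts and higher numbers for an effect only at larger amounts of compound), only through a limit, > 200000 nM. Among the compounds with values here, compound 2 `OC[C@@H](O[C@H]1CCCN(Cc2cccc3nonc23)[C@H]1c1ccccc1)c1cc(Cl)cc(Cl)c1` is the one compound with a number in this assay, where compound 2 gives 8000 nM; the other value shown sits at the limit of > 200000 nM in this assay, at which 1 of the 2 values shown sits. Compound 3 `CN1CCC[C@H](O[C@H](CO)c2cc(Cl)cc(Cl)c2)[C@@H]1c1ccccc1` differs from compound 2 by a hydrogen atom in place of a group of 9 heavy atoms (6 carbon, 2 nitrogen, 1 oxygen; one five-membered aromatic ring with 3 hetero atoms, one six-membered aromatic ring of carbon only), on a saturated chain carbon bound to an amine nitrogen in a ring. Within the data shown here, with no measured step between two compounds to set a scale, the step from compound 2 to compound 3 is expected to lose potency beyond the usual scatter, a 5.0-fold higher number from compound 2 to compound 3 (0.70 log units; beyond the scatter). Compound 3 is therefore estimated at 40000 nM in this assay, within a range from 8000 nM to 200000 nM.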

Compound 3, half-maximal effective concentration: 42000 nM
For compound 3 the middle estimate is 1.1-fold (0.02 log units) below the measured one; measured number inside the range.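

Placing a hydrogen on the saturated chain carbon bound to an amine nitrogen in a ring, in place of the group with two aromatic rings, costs potency in this assay, with a 5.3-fold higher number from compound 2 to compound 3 (0.72 log units; beyond the scatter). The group therefore adds to potency at this place, yet compound 3 still gives a number and not a limit, so the effect does not depend on this group alone. Nothing shown gives a cause for this step. The compounds shown leave open whether a simple phenyl ring, a pyridine or a longer alkyl chain at this place would serve as well as the two-ring group.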